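Acyl variation on the shared core: toward compound 4

The source may hold more compounds than are shown below. What is called first, only, known or untested is meant among the compounds shown, and "the series" means these compounds.

Measured so far in an assay (strain Wistar) for displacement of a labelled ligand from adenosine receptor A1 (Rattus norvegicus), read by scintillation counting; a higher number here means a weaker inhibitor, a lower number a stronger inhibitor:
compound 1 `Nc1nc(-c2ccccc2)nc2c1nnn2Cc1ccccc1` — 5.6 nM
compound 2 `O=C(Nc1nc(-c2ccccc2)nc2c1nnn2Cc1ccccc1)c1cccc([N+](=O)[O-])c1` — 77 nM
compound 3 `O=C(Nc1nc(-c2ccccc2)nc2c1nnn2Cc1ccccc1)C1CC1` — 7.5 nM

Compound 3 stands second highest of the three numbers. Its nearest neighbour is compound 1: the step of a 1.3-fold higher number from compound 1 to compound 3 (0.13 log units; within the scatter) lies within the scatter, so the two cannot be ordered. Its furthest neighbour is compound 2: the step of a 10-fold lower number from compound 2 to compound 3 (1.01 log units; beyond the scatter) is large and beyond the scatter.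

The next compound, compound 4 `O=C(Nc1nc(-c2ccccc2)nc2c1nnn2Cc1ccccc1)C1CCCC1`, differs from compound 3 in one place: cyclopentyl in place of cyclopropyl on a carbonyl carbon.

For the measured compounds named here, two measured steps bear on this change, both concerning the group on the carbonyl carbon. The step of a 14-fold higher number from compound 1 to compound 2 (1.14 log units; beyond the scatter) and the step of a 10-fold lower number from compound 2 to compound 3 (1.01 log units; beyond the scatter) show that the acyl group can move the number by a large amount, while a 1.3-fold higher number from compound 1 to compound 3 (0.13 log units; within the scatter) shows that a cyclopropylcarbonyl group leaves the number where the free amine of compound 1 has it. Cyclopentyl is a different case from either; no measured step of exactly this kind exists. A moderate rise in the number is therefore expected, possibly no more than the scatter, and the step from compound 3 to compound 4 is estimated at a 2.0-fold higher number from compound 3 to compound 4 (0.30 log units; within the scatter). Compound 4 is expected to give 15 nM, within a range of 5 nM to 45 nM.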

Compound 4, inhibition constant: 2.5 nM
Beside the measured number, compound 4's estimate is 6.0-fold (0.78 log units) above it, outside the stated range (below it).
By their numbers in this assay, from the lowest: compound 4; then compounds 1 and 3 (each within the scatter of the next); then compound 2.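

In this assay, an acyl group on the nitrogen on the aromatic ring can take the number below that of the free amine, as a 2.2-fold lower number from compound 1 to compound 4 (0.35 log units; beyond the scatter) shows, whereas the earlier acyl groups either left it level or raised it. Exchanging one non-aromatic carbon ring for another on the carbonyl carbon, with no hydrogen-bond donor or acceptor entering or leaving, still moves the number beyond the scatter, giving a 3.0-fold lower number from compound 3 to compound 4 (0.48 log units; beyond the scatter), while a 31-fold lower number from compound 2 to compound 4 (1.49 log units; beyond the scatter) is the largest step among these compounds and sets the two acyl types far apart. Nothing at hand explains either the direction or the size of these steps.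

As far as these compounds go, two carbon rings cannot fix a trend with ring size, so it remains open whether cyclohexyl or an open chain such as butyl on the carbonyl carbon would lower the number further or raise it again. With 3-nitrophenyl as the only aromatic acyl group, the compounds shown also do not separate the part played by the phenyl ring from that of the nitro group, which a plain phenyl or a methoxyphenyl group could address.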